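The source may hold more compounds than are shown below. What is called first, only, known or untested is meant among the compounds shown, and "the series" means these compounds.

Compound 3 `C[C@@H]1CN(C(=O)c2nc(Nc3cc(C4CC4)[nH]n3)c3cc(Cl)ccc3n2)CCN1C(=O)OCOC(=O)C(C)(C)C` gives 24.1% in an assay for inhibition of serine/threonine-protein kinase PAK 4 (Homo sapiens), read by FRET and Z'-LYTE, with a stated time of 60 min, tested at 5 uM, in the presence of a further agent that is not named here (a higher number here means a stronger effect of the compound at the concentration tested, a lower number a weaker effect), the lowest of the three values measured; compound 1 `CC(C)C(=O)OCOC(=O)N1CCN(C(=O)c2nc(Nc3cc(C4CC4)[nH]n3)c3cc(Cl)ccc3n2)C[C@H]1C` gives 51.6% and compound 2 `COC(=O)N1CCN(C(=O)c2nc(Nc3cc(C4CC4)[nH]n3)c3cc(Cl)ccc3n2)C[C@H]1C` gives 89.6%. Compound 4 `CC(C)OC(=O)N1CCN(C(=O)c2nc(Nc3cc(C4CC4)[nH]n3)c3cc(Cl)ccc3n2)C[C@H]1C` differs from compound 3 in one place: isopropyl in place of (((tert-butyl)carbonyl)oxy)methyl on an oxygen next to a carbonyl group. Among the measured compounds shown here, two measured steps bear on this. Putting hydrogen in place of (isopropylcarbonyl)oxy gave a large rise, a number 38 percentage points higher from compound 1 to compound 2 (beyond the scatter), while putting ((tert-butyl)carbonyl)oxy in place of hydrogen gave a large fall, a number 65.5 percentage points lower from compound 2 to compound 3 (beyond the scatter). Compound 4 carries neither group on its carbamate, so a large rise back towards the value of compound 2 is expected, a number 60.9 percentage points higher from compound 3 to compound 4 (beyond the scatter). Compound 4 is therefore estimated at 85%, within a range from 65% to 97%.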

Compound 4, a percentage reported as inhibition, at one concentration (the size of the read-out at that concentration, not a potency): 75.8%
Compound 4: the middle estimate sits 9.2 percentage points above what was measured; the measured number falls inside the stated range.
By their numbers in this assay, from the lowest: compound 3; then compound 1; then compound 4; then compound 2.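

In this assay, isopropyl on this oxygen gives a much higher number than (((tert-butyl)carbonyl)oxy)methyl (a number 51.7 percentage points higher from compound 3 to compound 4 (beyond the scatter)) and a higher number than ((isopropylcarbonyl)oxy)methyl (a number 24.2 percentage points higher from compound 1 to compound 4 (beyond the scatter)). Even a swap between two simple groups matters, since isopropyl in place of methyl lowers the number (a number 13.8 percentage points lower from compound 2 to compound 4 (beyond the scatter)), so the position responds to more than the two long groups. Nothing measured here explains these differences. From the compounds shown here alone, whether ethyl or tert-butyl on this oxygen would fit between or beyond these values stays open.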